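A few compounds are considered here, and "the series" means these few. Any claim that something is new, unique, unknown or untested is made for them only; others in the source may bear on it.

Going by the values given here, compound 3 `N#Cc1cccc(S(=O)(=O)N(Cc2ccc(F)cc2)C[C@@H]2CCC(=O)N2)c1` gives 2.7 in a physicochemical assay for lipophilicity (a lower number here means a more polar compound, a higher number a more lipophilic compound), and sits level with compound 1 `O=C1CC[C@@H](CN(Cc2ccc(F)cc2)S(=O)(=O)c2ccccc2)N1` at 2.7 as the lowest number so far, while compound 2 `COc1cccc(S(=O)(=O)N(Cc2ccc(F)cc2)C[C@@H]2CCC(=O)N2)c1` reads 3.1 as the highest. Between compound 3 and compound 4 `N#Cc1cccc(S(=O)(=O)N(Cc2ccc(F)cc2)C[C@H]2CCC(=O)N2)c1` the change is the two compounds have the same atoms and bonds and differ only in configuration as drawn: 1 of 1 stereo elements differ; a stereocentre at a saturated ring carbon is drawn S in compound 3 and R in compound 4 and nothing leaves or enters: a stereocentre at a saturated ring carbon is drawn S in compound 3 and R in compound 4. The measured steps are all changes on an aromatic carbon: a number 0.40 log units higher from compound 1 to compound 2 (beyond the scatter) with methoxy in place of hydrogen, no change at the digits printed from compound 1 to compound 3 (within the scatter) with cyano in place of hydrogen and a number 0.40 log units lower from compound 2 to compound 3 (beyond the scatter) with cyano in place of methoxy. None of them alters configuration, so they bear on compound 4 only indirectly, and no step beyond the scatter is expected in this assay in either direction. The expected step is no change at the digits printed from compound 3 to compound 4 (within the scatter) and no direction is favoured. Compound 4 is estimated at 2.7 with an expected range from 2.5 to 2.9 for this measurement.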

Compound 4, distribution coefficient: 2.5
For compound 4 the middle estimate is 0.20 log units above the measured one; measured number inside the range.
By their numbers in this assay, from the lowest: compounds 4, 1 and 3 (each within the scatter of the next); then compound 2.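

In this assay, going by these compounds alone, the stereocentre at the saturated ring carbon is probed for the first time, giving a number 0.20 log units lower from compound 3 to compound 4 (within the scatter). Within the data shown here, the earlier steps all sit on an aromatic carbon, so this pair is the only reading of S against R as drawn, and at this position this assay does not separate the two configurations. The comparison is a clean one, with nothing leaving or entering: the fact that compounds 3 and 4 differ only in the configuration as drawn

On these data alone, both configurations appear only with the cyano group, so whether the same holds with the methoxy group of compound 2 or the hydrogen of compound 1 stays open. Also open, as far as these compounds go, is how the two configurations would compare with an amine or a carboxylic acid on that aromatic carbon.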